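The source may hold more compounds than are shown below. What is called first, only, known or untested is meant among the compounds shown, and "the series" means these compounds.

Working notes on the series in an ADME assay on HUVEC cells (Homo sapiens) for antiproliferative activity, read by MTT assay, with a stated time of 48 h; a higher number here means a weaker inhibitor, a lower number a stronger inhibitor.

For the measured compounds named here, compound 3 `N#CC1=C(N)Oc2c(N)cc3nc4ccccc4nc3c2C12C(=O)N(Cc1cnnn1-c1ccccc1Br)c1ccccc12` is the one member of the set that gives a number, 34200 nM. Compound 1 `N#CC1=C(N)Oc2c(N)cc3nc4ccccc4nc3c2C12C(=O)N(Cc1cnnn1-c1ccc(F)cc1)c1ccccc12` sits at a limit of this assay, > 50000 nM. Compound 2 `N#CC1=C(N)Oc2c(N)cc3nc4ccccc4nc3c2C12C(=O)N(Cc1cnnn1-c1ccc(Cl)cc1)c1ccccc12` likewise sits at a limit, > 50000 nM. Two of the three values therefore rest on (the limit of > 50000 nM in this assay, at which 2 of the 3 values shown sit), and compound 3 stands as the only measured point. The measured steps are an at least 1.4-fold lower number from compound 1 to compound 3 (0.16 log units; that floor lies within the scatter) and an at least 1.4-fold lower number from compound 2 to compound 3 (0.16 log units; that floor lies within the scatter); both carry a floor that lies within the scatter, and the step that the two limits leave unreadable from compound 1 to compound 2 is not readable at all.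

Compound 4 `COc1ccc(-n2nncc2CN2C(=O)C3(C(C#N)=C(N)Oc4c(N)cc5nc6ccccc6nc5c43)c3ccccc32)cc1` differs from compound 3 by 4-methoxyphenyl in place of 2-bromophenyl on an aromatic nitrogen. Going by the values given here, no measured step covers a methoxy group or this exchange; what can be said is that the entering 4-methoxyphenyl is, like the 4-fluorophenyl of compound 1 and the 4-chlorophenyl of compound 2, a singly substituted phenyl, and both of those compounds reached only a limit of this assay. On that basis compound 4 is expected to move back toward the limit, a step of a 1.5-fold higher number from compound 3 to compound 4 (0.16 log units; within the scatter) whose size cannot be fixed by the data, and a limit rather than a number is judged somewhat more likely than not. The estimate for compound 4 is 50000 nM, within 20000 nM to 120000 nM, pending the measurement.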

Compound 4, half-maximal inhibitory concentration: > 50000 nM
Compound 4 gave a limit, no number; the forecaster's own chance of this, stated with the estimate: 55%; the middle value lies on the limit itself.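

In this assay, 4-methoxyphenyl in place of 2-bromophenyl on the aromatic nitrogen gives an at least 1.4-fold higher number from compound 3 to compound 4 (0.16 log units; that floor lies within the scatter), so even this exchange does not separate compound 4 from compound 3 beyond the scatter. For the compounds shown here, this is the first group at this position with a methoxy rather than a halogen on the phenyl, and it too gives a limit and no number, which leaves compound 3 as the only compound with a number. The steps from compound 1 and from compound 2 to compound 4 cannot be read, and compound 1, compound 2 and compound 4, all with a 4-substituted phenyl, share one limit, compound 3 with its 2-bromophenyl being the exception: the limit of > 50000 nM in this assay, at which 3 of the 4 values shown sit.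

Whether the number for compound 3 goes with the bromine or with the place of the substituent on the phenyl stays open, as the compounds shown include neither a 4-bromophenyl nor a 2-methoxyphenyl. Also open, on these data alone, is how this position responds to a plain phenyl, or to a phenyl carrying an amine or a carboxylic acid.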